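Replacing a Thioether with a Sulfone at the Benzylic Position

The source may hold more compounds than are shown below. What is called first, only, known or untested is meant among the compounds shown, and "the series" means these compounds.

The study compares compounds sharing one core. Compound 1 `Cc1nc2c(OCc3ccccc3)cccn2c1CO` carries a hydroxy group on a saturated chain carbon bound to an aromatic carbon; in a functional assay on the whole organism with Rattus norvegicus as the target, with a stated time of 4 h, at a dose of 40 mg/kg by the intraperitoneal route (on this read-out lower numbers stand for less inhibition and higher numbers for more inhibition at the one dose given (going by the name of the read-out)), compound 1 gives 99%. Compound 2 `CCSCc1c(C)nc2c(OCc3ccccc3)cccn12` carries ethylsulfanyl at that same place and in this assay compound 2 gives 36%, the lower of the two numbers. Among the measured compounds shown here, the only measured step is a number 63 percentage points lower from compound 1 to compound 2 (beyond the scatter), showing that swapping the group at this carbon can move the number a great deal. Compound 3 `Cc1nc2c(OCc3ccccc3)cccn2c1CS(C)(=O)=O` differs from compound 2 by methylsulfonyl in place of ethylsulfanyl on a saturated chain carbon bound to an aromatic carbon. For the measured compounds named here, no measured step covers ethylsulfanyl turning into methylsulfonyl, so the direction is uncertain; the one known step only shows that changes here can be large. Compound 3 is therefore expected to sit around 60%, within 20% to 95%, an estimated step of a number 24 percentage points higher from compound 2 to compound 3 (beyond the scatter) from compound 2.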

Compound 3, a percentage reported as inhibition, in the whole organism at one dose (the size of the read-out at that dose, not a potency): 61%
Beside the measured number, compound 3's estimate is 1 percentage points below it; the measured number falls inside the stated range.
By their numbers in this assay, from the lowest: compound 2; then compound 3; then compound 1.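

In this assay, methylsulfonyl in place of ethylsulfanyl gives a number 25 percentage points higher from compound 2 to compound 3 (beyond the scatter), so a sulfur-bearing group on this saturated chain carbon does not fix the number at one low level. The change recovers only part of the gap, however: methylsulfonyl in place of hydroxy still gives a number 38 percentage points lower from compound 1 to compound 3 (beyond the scatter), and hydroxy keeps the highest number of the three groups. No measurement at hand explains these differences.

The compounds shown leave open whether the rise goes with the oxygens of the sulfonyl or with methyl in place of ethyl, a question that methylsulfanyl or ethylsulfonyl at this carbon would separate. Also open, on these data alone, is whether another group here, such as an amine or a carboxylic acid, could match hydroxy.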